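The compounds below may be only part of what the source reports. "The series", "measured", "known", "first", "only" and "open" are said of these compounds alone.

Compound 1 `CCNC(=O)Nc1c(OCCCn2cnc(-c3ccccc3)c2)cccc1N(C)C` gives in an assay on aorta for inhibition of acyl-CoA:cholesterol acyltransferase (Oryctolagus cuniculus) (a higher number here means a weaker inhibitor, a lower number a stronger inhibitor), only a limit, > 10000 nM.
Compound 2 `CCCNC(=O)Nc1c(OCCCn2cnc(-c3ccccc3)c2)cccc1N(C)C` gives 7230 nM.
Compound 3 `CN(C)c1cccc(OCCCn2cnc(-c3ccccc3)c2)c1NC(=O)NC1CCCCC1` gives 1070 nM.

Compound 3 holds the lowest of the two numbers; the nearest is compound 2, with a 6.8-fold lower number from compound 2 to compound 3 (0.83 log units; beyond the scatter). The step of an at least 9.3-fold lower number from compound 1 to compound 3 (0.97 log units; beyond the scatter) rests on the limit (the limit of > 10000 nM in this assay, at which 1 of the 3 values shown sits), so only its floor is known. Compound 4 `CN(C)c1cccc(OCCCn2cnc(-c3ccccc3)c2)c1NC(=O)NC1CCCC1` differs from compound 3 by cyclopentyl in place of cyclohexyl on an amide-type nitrogen. The measured steps on this nitrogen, a 6.8-fold lower number from compound 2 to compound 3 (0.83 log units; beyond the scatter) and an at least 9.3-fold lower number from compound 1 to compound 3 (0.97 log units; beyond the scatter), each swap a chain for a ring; none compares the two ring sizes, and the chain step an at least 1.3-fold lower number from compound 1 to compound 2 (0.14 log units; that floor lies within the scatter) stays within the scatter. For compound 4 a small step is therefore expected, a 1.4-fold higher number from compound 3 to compound 4 (0.15 log units; within the scatter), likely within the scatter. Compound 4 is estimated at 1500 nM, between 600 nM and 4000 nM.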

Compound 4, half-maximal inhibitory concentration: 3530 nM
Compound 4: the middle estimate sits 2.4-fold (0.37 log units) below what was measured; the measured number falls inside the stated range.
By their numbers in this assay, from the lowest: compound 3; then compound 4; then compound 2. At a limit, above all of these: compound 1.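

Ring size on this amide-type nitrogen matters, which the earlier chain-to-ring steps could not show: cyclopentyl in place of cyclohexyl is beyond the scatter (a 3.3-fold higher number from compound 3 to compound 4 (0.52 log units; beyond the scatter)). Cyclopentyl still gives a lower number than propyl (a 2.0-fold lower number from compound 2 to compound 4 (0.31 log units; beyond the scatter)), so the numbers fall from propyl through cyclopentyl to cyclohexyl. Compound 1 stands at a limit, so the step from ethyl (an at least 2.8-fold lower number from compound 1 to compound 4 (0.45 log units; beyond the scatter)) is only a floor: the limit of > 10000 nM in this assay, at which 1 of the 4 values shown sits.

Still open, as far as these compounds go, is whether cycloheptyl on this nitrogen would go below cyclohexyl. The effect of an aromatic phenyl or a branched tert-butyl here is also unknown.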